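The source may hold more compounds than are shown below. What is called first, only, known or untested is meant among the compounds shown, and "the series" means these compounds.

Measured so far:
Compound 1, `CC(C)c1cccc(OCC(=O)Nc2ccc(OCC(=O)O)c(F)c2)c1`: 43.3%
Compound 2, `CC(C)(C)c1cccc(OCC(=O)Nc2ccc(OCC(=O)O)c(F)c2)c1`: 40.2%
Compound 3, `Cc1ccc(C(C)C)cc1OCC(=O)Nc1ccc(OCC(=O)O)c(F)c1`: 14.6%

All three share a core and were tested in a functional assay on CHO cells for agonist activity at Free fatty acid receptor 1 (Homo sapiens), read by FLIPR, tested at 100 nM; on this read-out higher numbers stand for a stronger effect at the one concentration tested and lower numbers for a weaker effect. Compound 3 differs from compound 1 by methyl in place of hydrogen on an aromatic carbon, a change that gave a number 28.7 percentage points lower from compound 1 to compound 3 (beyond the scatter). Compound 2 differs from compound 1 by methyl in place of hydrogen on a saturated chain carbon bound to an aromatic carbon and two saturated chain carbons, which gave a number 3.1 percentage points lower from compound 1 to compound 2 (within the scatter). Compound 4, `Cc1ccc(C(C)C)cc1OC(C)C(=O)Nc1ccc(OCC(=O)O)c(F)c1`, has not been measured; it differs from compound 3 by methyl in place of hydrogen on a saturated chain carbon bound to a carbonyl carbon and an oxygen on an aromatic ring. Among the measured compounds shown here, this is the same kind of change as the one between compound 1 and compound 2, but not the same: there the place was a saturated chain carbon bound to an aromatic carbon and two saturated chain carbons, here it is a saturated chain carbon bound to a carbonyl carbon and an oxygen on an aromatic ring. Given that the earlier added methyl gave a number 3.1 percentage points lower from compound 1 to compound 2 (within the scatter), the step expected in this assay for compound 4 is a number 2.6 percentage points lower from compound 3 to compound 4 (within the scatter), with the differing place adding uncertainty. Compound 4 is therefore estimated at 12%, likely between 2% and 30%.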

Compound 4, a percentage reported as activity, at one concentration (the size of the read-out at that concentration, not a potency): 19.4%
Compound 4: middle estimate off by 7.4 percentage points, on the low side; measured number inside the range.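

In this assay, methyl in place of hydrogen on the saturated chain carbon bound to a carbonyl carbon and an oxygen on an aromatic ring gave a number 4.8 percentage points higher from compound 3 to compound 4 (within the scatter). Set beside the earlier methyl step, the result gives no sign that this kind of change behaves differently on the two cores: the same change on two cores in this assay, a number 3.1 percentage points lower (within the scatter) from compound 1 to compound 2 and a number 4.8 percentage points higher (within the scatter) from compound 3 to compound 4, 7.9 percentage points apart, within the scatter of two such steps. Among the compounds shown here, this rests on only two pairs, with the methyl at a different place in each, so it does not show that the same small effect would carry over to other places or cores.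

The compounds shown leave open what an ethyl, a hydroxyl or an amine would do at this chain carbon. They also leave open how this methyl would behave on the core of compound 1.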